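Shrinking the benzofuran on a nucleoside scaffold

A few compounds are considered here, and "the series" means these few. Any claim that something is new, unique, unknown or untested is made for them only; others in the source may bear on it.

Compound 2 `O=c1[nH]cnc2c1c(-c1cc3ccccc3o1)cn2[C@@H]1O[C@H](CO)[C@@H](O)[C@H]1O` carries a 1-benzofuran-2-yl group and, in an ADME assay on BJ cells (Homo sapiens), read by MTT assay, with a stated time of 72 h (a higher number here means a weaker inhibitor, a lower number a stronger inhibitor), compound 2 gives 62700 nM. Compound 3 `CNc1ncnc2c1c(-c1cc3ccccc3o1)cn2[C@@H]1O[C@H](CO)[C@@H](O)[C@H]1O` bears the same group on a different core; the difference between the two cores is not broken down here. In this assay compound 3 gives 75600 nM, which sits within the scatter of the value of compound 2. Compound 1 `O=c1[nH]cnc2c1c(-c1ccco1)cn2[C@@H]1O[C@H](CO)[C@@H](O)[C@H]1O` differs from compound 2 by furan-2-yl in place of 1-benzofuran-2-yl on an aromatic carbon. In this assay compound 1 gives > 100000 nM, which is a limit of the assay and not a number, (the limit of > 100000 nM in this assay, at which 1 of the 3 values shown sits). This change produced an at least 1.5-fold higher number from compound 2 to compound 1 (0.20 log units; that floor lies within the scatter). Compound 4 `CNc1ncnc2c1c(-c1ccco1)cn2[C@@H]1O[C@H](CO)[C@@H](O)[C@H]1O` has not been measured; it differs from compound 3 by furan-2-yl in place of 1-benzofuran-2-yl on an aromatic carbon, the same change as that from compound 2 to compound 1. Compound 4 is expected to show a 2.0-fold higher number from compound 3 to compound 4 (0.30 log units; within the scatter) because the same change gave an at least 1.5-fold higher number from compound 2 to compound 1 (0.20 log units; that floor lies within the scatter). The estimate for compound 4 in this assay is therefore 150000 nM, with a range from 75000 nM to 400000 nM, and the assay may well report only a limit.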

Compound 4, half-maximal inhibitory concentration: 5040 nM
Compound 4: middle estimate off by 30-fold (1.47 log units), on the high side, and the stated range ends above it.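

In this assay, furan-2-yl in place of 1-benzofuran-2-yl gave a 15-fold lower number from compound 3 to compound 4 (1.18 log units; beyond the scatter), and this does not match what the same change did on the core of compound 1: the same change on two cores in this assay, an at least 1.5-fold higher number (0.20 log units; that floor lies within the scatter) from compound 2 to compound 1 and a 15-fold lower number (1.18 log units; beyond the scatter) from compound 3 to compound 4, at least 23-fold (1.37 log units) apart, beyond the scatter of two such steps. Compound 1 stands at a limit of the assay and not at a number: the limit of > 100000 nM in this assay, at which 1 of the 4 values shown sits. The two pairs show that, in this series, the effect of this change in this assay cannot be carried from one core to the other, but they do not show which feature of the cores lies behind the difference, and two pairs set no rule for any further core.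

The compounds shown leave open whether the low number of compound 4 would hold with an ethylamino group or a plain amine on that core in place of the one it carries. They also leave open whether a thiophen-2-yl or phenyl group in place of furan-2-yl would give a similar number on either core.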